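Series notes: dropping the chloro from compound 2

A few compounds are considered here, and "the series" means these few. Any claim that something is new, unique, unknown or untested is made for them only; others in the source may bear on it.

compound 1 `CCN(CC)Cc1ccc2oc(=O)c(C(=O)Nc3ccccc3)cc2c1`: 14%
compound 2 `O=C(Nc1ccc(Cl)cc1O)c1cc2cc(Cl)cc(Br)c2oc1=O`: 99%

In an assay on isolated protein for inhibition of coagulation factor XII (Homo sapiens), read by HPLC, with stated times of 10 min and 30 min, tested at 50 uM (a lower number here means less inhibition, a higher number more inhibition at the concentration tested (going by the name of the read-out)), compound 1 gives 14%. In this assay compound 2 gives 99%, the higher of the two numbers, and its gap to compound 1 lies beyond the usual scatter. Compound 3 `O=C(Nc1ccccc1O)c1cc2cc(Cl)cc(Br)c2oc1=O` is not yet measured. It differs from compound 2 in one place: hydrogen in place of chloro on an aromatic carbon. Among the compounds with values here, no measured pair shows this change. Since compound 2 already sits at 99%, near the top of the scale, only a modest loss is expected, and the step of a number 14 percentage points lower from compound 2 to compound 3 (beyond the scatter) is expected to be downward, possibly within the scatter. Compound 3 is estimated at 85%, with a range from 55% to 99%.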

Compound 3, a percentage reported as inhibition, at one concentration (the size of the read-out at that concentration, not a potency): 99%
Compound 3: middle estimate off by 14 percentage points, on the low side; the range from low to high includes it.
By their numbers in this assay, from the lowest: compound 1; then compounds 2 and 3 (each within the scatter of the next).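

In this assay, replacing 4-chloro-2-hydroxyphenyl with 2-hydroxyphenyl gives no change at the digits printed from compound 2 to compound 3 (within the scatter) and shows that the chloro is not required for a reading near the top of the scale. At a single concentration so close to the top, this reading cannot show whether potency differs between the two compounds. Nothing measured here explains the result. Open, on these data alone, is whether a methoxy group, an amine or a carboxylic acid at this position would keep the reading. As far as these compounds go, the contribution of the neighbouring hydroxy group also remains open.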